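Sulfonyl aryl variation in the shared core series

A few compounds are considered here, and "the series" means these few. Any claim that something is new, unique, unknown or untested is made for them only; others in the source may bear on it.

Three analogues sharing one core have been measured. Compound 1 `O=S(=O)(NCCCNc1nccc(-c2c(-c3cccc(F)c3)nc3sccn23)n1)c1ccc(F)cc1` carries a 4-fluorophenyl sulfonyl on the longer chain; in a functional assay on A-375 cells (Homo sapiens) for cytotoxicity, read by MTT assay (a lower number here means a stronger inhibitor, a higher number a weaker inhibitor), compound 1 gives 14500 nM. Compound 2 `O=S(=O)(NCCNc1nccc(-c2c(-c3cccc(F)c3)nc3sccn23)n1)c1ccc(Br)cc1` shortens the chain and carries a 4-bromophenyl sulfonyl; in this assay compound 2 gives 13500 nM. Compound 3 `O=S(=O)(NCCNc1nccc(-c2c(-c3cccc(F)c3)nc3sccn23)n1)c1ccc(C(F)(F)F)cc1` carries a 4-(trifluoromethyl)phenyl sulfonyl, and in this assay compound 3 gives 7440 nM, the lowest of the three numbers, though its steps to both neighbours stay within the scatter.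

Going by the values given here, the steps so far: a 1.1-fold lower number from compound 1 to compound 2 (0.03 log units; within the scatter) and a 1.8-fold lower number from compound 2 to compound 3 (0.26 log units; within the scatter). Neither change at the sulfonyl aryl, nor the chain change, moved the number beyond the scatter.

Compound 4 `O=S(=O)(NCCNc1nccc(-c2c(-c3cccc(F)c3)nc3sccn23)n1)c1cccc(F)c1` is not yet measured. Its change from compound 3: 3-fluorophenyl in place of 4-(trifluoromethyl)phenyl on a sulfonyl sulfur. This again alters only the sulfonyl aryl, the kind of change that in the steps from compound 1 to compound 2 and from compound 2 to compound 3 gave no movement beyond the scatter. A step within the scatter is therefore expected, with no clear direction, and the estimate is a 1.5-fold higher number from compound 3 to compound 4 (0.17 log units; within the scatter). Compound 4 is expected to give 11000 nM in this assay, within the range 4500 nM to 27000 nM.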

Compound 4, half-maximal inhibitory concentration: 14900 nM
Compound 4: middle estimate off by 1.4-fold (0.13 log units), on the low side, within the range that was stated.
By their numbers in this assay, from the lowest: compounds 3, 2, 1 and 4 (each within the scatter of the next).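

The sulfonyl aryl position now tolerates a change of substituent and of its place on the ring without a clear shift in this assay: with 3-fluorophenyl in place of 4-(trifluoromethyl)phenyl on the sulfonyl sulfur, the result is a 2.0-fold higher number from compound 3 to compound 4 (0.30 log units; within the scatter). The comparison with the 4-bromophenyl group gives a 1.1-fold higher number from compound 2 to compound 4 (0.04 log units; within the scatter), and the change that takes in both the chain and the sulfonyl aryl gives a 1.0-fold higher number from compound 1 to compound 4 (0.01 log units; within the scatter), so the four compounds cannot be ranked and none of the aryl groups shown stands apart from the others. No measurement is available that could explain this flat response at the sulfonyl aryl.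

The compounds shown leave open whether an aryl ring carrying an amine or a carboxylic acid, or a simple methyl on the sulfonyl sulfur in place of the aryl ring, would move the number beyond the scatter. They also leave open whether a longer chain than that of compound 1, or replacement of the 3-fluorophenyl on the shared core, would do so.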